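From an Ethyl Ester to a Hydroxymethyl Group

The compounds below may be only part of what the source reports. "The series", "measured", "known", "first", "only" and "open" are said of these compounds alone.

Compound 2 `C/C=C/C(=O)Nc1ccc(Cn2nc(-c3ccc(Oc4ccccc4)cc3)cc2C(=O)OCC)cc1` carries an ethyl ester on its shared core. In a functional assay on Z-138 cells (Homo sapiens) for inhibition, read by luminescence and CellTiter-Glo, with a stated time of 72 h (a lower number here means a stronger inhibitor, a higher number a weaker inhibitor), compound 2 gives only a limit, > 60000 nM. Its acid partner, compound 1 `C/C=C/C(=O)Nc1ccc(Cn2nc(-c3ccc(Oc4ccccc4)cc3)cc2C(=O)O)cc1`, likewise gives only a limit, > 60000 nM. The step that the two limits leave unreadable from compound 1 to compound 2 therefore cannot be read, and both values sit at the limit of > 60000 nM in this assay, at which 2 of the 2 values shown sit. Compound 3 `C/C=C/C(=O)Nc1ccc(Cn2nc(-c3ccc(Oc4ccccc4)cc3)cc2CO)cc1` turns the ester into an alcohol: hydroxymethyl in place of ethoxycarbonyl on an aromatic carbon. For the measured compounds named here, no measured step bears on this change, so the expected step of a number no higher from compound 2 to compound 3 (the limit leaves the size open) rests on no measured guide. Compound 3 is therefore estimated at 60000 nM, with a range from 8000 nM to 200000 nM, and another limit is the likeliest outcome.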

Compound 3, half-maximal inhibitory concentration: 54500 nM
Estimate against measurement, compound 3: 1.1-fold (0.04 log units) above, and the stated range covers the measured number.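

Compound 3 is the only one of the three compounds in this assay that gives a number rather than a limit, so this position now has one readable value: the limit of > 60000 nM in this assay, at which 2 of the 3 values shown sit.

Hydroxymethyl in place of ethoxycarbonyl gives an at least 1.1-fold lower number from compound 2 to compound 3 (0.04 log units; that floor lies within the scatter), and hydroxymethyl in place of carboxy gives an at least 1.1-fold lower number from compound 1 to compound 3 (0.04 log units; that floor lies within the scatter). Both are floors, so neither change is shown to matter beyond the scatter, and their true sizes remain unknown.

Going by these compounds, whether an amine or a longer chain on this aromatic carbon would give a clearly lower number stays open.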